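Swapping the aryl group on a pyrazolopyridine kinase binder

This account rests on a few compounds, and the source may have more. Where it says the series, first, only, none or still open, it means among the compounds named here.

Compound 2 `CCCS(=O)(=O)Nc1ccc(F)c(C(=O)c2n[nH]c3ncc(-c4ccc(F)cc4C)cc23)c1F` was measured in an assay for binding affinity to dual specificity mitogen-activated protein kinase kinase 4 (Homo sapiens), read by KINOMEscan, tested at 100 nM (on this read-out higher numbers stand for a weaker effect at the one concentration tested and lower numbers for a stronger effect), and gives 14%. For the measured compounds named here, its only measured neighbour is compound 1 `CCCS(=O)(=O)Nc1ccc(F)c(C(=O)c2n[nH]c3ncc(-c4ccc(C)cc4)cc23)c1F`, which in this assay gives 5.4%; the step of a number 8.6 percentage points higher from compound 1 to compound 2 (within the scatter) lies within the scatter, so the two numbers cannot be told apart. Compound 3 `CCCS(=O)(=O)Nc1ccc(F)c(C(=O)c2n[nH]c3ncc(-c4cccc([N+](=O)[O-])c4)cc23)c1F` has not been measured. It differs from compound 2 by 3-nitrophenyl in place of 4-fluoro-2-methylphenyl on an aromatic carbon. Going by the values given here, no measured step exchanges this part of the molecule for a nitrophenyl group, so the only guide is that the two aryl groups already tested both leave binding strong. On that basis a small step of a number 1 percentage points higher from compound 2 to compound 3 (within the scatter) is expected, with no clear direction beyond the scatter. Compound 3 is therefore estimated to give 15% in this assay, within a range from 3% to 45%.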

Compound 3, a percentage reported as activity, at one concentration (the size of the read-out at that concentration, not a potency): 15%
The estimate for compound 3 equals the measured number at the digits printed; low and high end bracket the measured number.
By their numbers in this assay, from the lowest: compounds 1, 2 and 3 (each within the scatter of the next).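

In this assay, the step of a number 1 percentage points higher from compound 2 to compound 3 (within the scatter) shows that this aromatic carbon can carry 3-nitrophenyl, with its 2 hydrogen-bond acceptors, in place of 4-fluoro-2-methylphenyl, which has none, without a change that can be told from the scatter. The comparison with the other aryl group reads the same way, with the step of a number 9.6 percentage points higher from compound 1 to compound 3 (within the scatter) also lying within the scatter. Until now, both aryl groups at this position carried a methyl group, whereas compound 3 has none and still cannot be told apart from compound 1 or compound 2.

On these data alone, it remains open whether an amine or a carboxylic acid on this ring, or a longer alkyl chain in place of the ring, would keep the number in this range. Nothing in the data explains why these three numbers lie so close together.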